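A Bulkier Amide on a Weak Cytotoxic Hydrazone

The source may report more compounds than this note shows. Statements on the series, on what has been measured and on what is new or still open speak of the compounds shown alone.

Compound 1 `C/C(=N\NC(=O)CC#N)c1ccc(S(=O)(=O)N2CCCCC2)cc1` is one of three hydrazone-bearing sulfonamides assessed in a functional assay on MCF7 cells (Homo sapiens) for cytotoxicity, read by sulforhodamine B assay, with a stated time of 48 h; a lower number here means a stronger inhibitor, a higher number a weaker inhibitor. In this assay compound 1 gives 44200 nM, the highest of the three numbers, though within the scatter of compound 2 `CCOC(=O)c1c(-c2ccc(N(C)C)cc2)c(C#N)c(=O)n(/N=C(\C)c2ccc(S(=O)(=O)N3CCCCC3)cc2)c1N`, which gives 34400 nM, and of compound 3 `C/C(=N\n1c(N)cc(N)c(C#N)c1=O)c1ccc(S(=O)(=O)N2CCCCC2)cc1`, which gives 36400 nM. Compound 4 `C/C(=N\NC(=O)c1sc2c(c1N)CCC2)c1ccc(S(=O)(=O)N2CCCCC2)cc1` differs from compound 1 in one place: a group of 9 heavy atoms (7 carbon, 1 nitrogen, 1 sulfur; one five-membered non-aromatic ring of carbon only, one five-membered aromatic ring with 1 hetero atom) in place of a group of 3 heavy atoms (2 carbon, 1 nitrogen; no ring), on a carbonyl carbon. Within the data shown here, no measured pair isolates a change of this kind, so its effect rests on judgement alone. A modest move toward a lower number is expected, as the step of a 2.0-fold lower number from compound 1 to compound 4 (0.30 log units; within the scatter), with no confidence that it exceeds the scatter. Compound 4 is expected to give 22000 nM in this assay, within 6000 nM to 70000 nM.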

Compound 4, half-maximal inhibitory concentration: 75300 nM
Estimate against measurement, compound 4: 3.4-fold (0.53 log units) below; the measured number lies above the stated range.
By their numbers in this assay, from the lowest: compounds 2, 3, 1 and 4 (each within the scatter of the next, the first and the last beyond it).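

At this carbonyl carbon, the enlarged group in place of cyanomethyl gives a 1.7-fold higher number from compound 1 to compound 4 (0.23 log units; within the scatter) in this assay. The position thus accepts a group with two rings, a sulfur atom and a hydrogen-bond donor without a change that stands clear of the scatter, and the larger group brings no gain in this read-out. Nothing measured here offers an explanation for this result.

On these data alone, whether a small group such as methyl, a carboxylic acid or a longer alkyl chain on this carbonyl carbon would move the number beyond the scatter remains open. The compounds shown also leave open which part of the larger group, if any, matters.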